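The source may report more compounds than this note shows. Statements on the series, on what has been measured and on what is new or still open speak of the compounds shown alone.

Compound 1, `Nc1ccc(Oc2ccccc2-c2ccc(S(=O)(=O)NCCNC(=O)Nc3ccc(Cl)cc3)s2)cc1`, in a functional assay on HeLa cells (Homo sapiens) for inhibition, read by CCK-8 assay, with a stated time of 48 h (a lower number here means a stronger inhibitor, a higher number a weaker inhibitor), gives > 20000 nM, which is a limit of the assay.
Compound 2, `O=[N+]([O-])c1ccc(NC(=S)NCCNS(=O)(=O)c2ccc(-c3ccccc3OCc3ccccc3)s2)cc1`, in this assay gives 7100 nM.
Compound 3, `CC(C)c1ccc(Oc2ccc(O)c(O)c2)c(-c2ccsc2S(=O)(=O)NCCNC(=O)Nc2cc(C(F)(F)F)cc(C(F)(F)F)c2)c1`, in this assay gives > 50000 nM, which again is a limit.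

Of the three values shown, only compound 2 comes with a number; compound 1 and compound 3 stop at limits, so compound 1 cannot be placed against compound 2 beyond saying that its value sits at the limit of > 20000 nM in this assay, at which 1 of the 3 values shown sits, while compound 2 gives a measured inhibition. Compound 3 sits at the limit of > 50000 nM in this assay, at which 1 of the 3 values shown sits, in a sentence of its own.

Compound 4, `O=C(NCCNS(=O)(=O)c1ccc(-c2ccccc2Oc2ccc([N+](=O)[O-])c([N+](=O)[O-])c2)s1)Nc1ccc(Cl)cc1`, comes from compound 1 by one change: 3,4-dinitrophenyl in place of 4-aminophenyl on an oxygen on an aromatic ring. Going by the values given here, no step between measured compounds is available to size this change, so the expectation rests on the three values alone. In this assay the step is expected to be small, possibly in the direction of stronger inhibition, but most likely not beyond the scatter given that compound 1 is only known as a limit. Compound 4 is expected to give about 15000 nM, with a range from 4000 nM to 50000 nM. The step this implies, an at least 1.3-fold lower number from compound 1 to compound 4 (0.12 log units; that floor lies within the scatter), is an estimate and not a measurement.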

Compound 4, half-maximal inhibitory concentration: > 20000 nM
Compound 4: no number, only a limit; the forecaster's own chance of this, stated with the estimate: 50%; middle value at least 1.3-fold (0.12 log units) from the limit.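

In this assay compound 4 stops at a limit, as compound 1 does, so no step from compound 1 to compound 4 can be read: the limit of > 20000 nM in this assay, at which 2 of the 4 values shown sit.

The compounds shown leave open how far, if at all, 3,4-dinitrophenyl in place of 4-aminophenyl shifts the value in this assay, as neither compound has a measured number.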